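Chloro in place of dimethylamino on the shared core

A few compounds are considered here, and "the series" means these few. Any claim that something is new, unique, unknown or untested is made for them only; others in the source may bear on it.

Among the measured compounds shown here, compound 1 `CN(C)c1nccc2c1ncn2C1O[C@H](CO)[C@@H](O)[C@H]1O` and compound 2 `C[C@H]1OC(n2cnc3c(N)nccc32)[C@H](O)[C@@H]1O` are the two compounds with numbers so far. In a functional assay on EL4 cells (Mus musculus) for inhibition, tested at 100 uM (on this read-out higher numbers stand for more inhibition at the one concentration tested (going by the name of the read-out) and lower numbers for less inhibition), compound 1 gives 10%, and compound 2 gives 32%. Compound 1 thus stands lowest of the two; its nearest neighbour, compound 2, sits higher by a margin beyond the usual scatter. For the measured compounds named here, compound 2 differs from compound 1 in more than one place, so the pair shows only that a compound of this core can reach the higher figure.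

Compound 3 `OC[C@H]1OC(n2cnc3c(Cl)nccc32)[C@H](O)[C@@H]1O` has not yet been measured in this assay. It departs from compound 1 by chloro in place of dimethylamino on an aromatic carbon, on an aromatic carbon of the six-membered aromatic ring with one nitrogen within the shared core. Going by the values given here, no measured pair covers such an exchange, so the direction of the step is open. A small rise, or none beyond the scatter, is expected: a number 6 percentage points higher from compound 1 to compound 3 (within the scatter). Compound 3 is expected to give 16% in this assay, with a range from 0% to 40%.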

Compound 3, a percentage reported as inhibition, at one concentration (the size of the read-out at that concentration, not a potency): < 5%
Compound 3 was reported as a limit; the forecaster's own chance of this, stated with the estimate: 0%; at least 11 percentage points between middle value and limit.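

In this assay compound 3 gives < 5%, which is a limit of the assay and not a number. Among the compounds shown here, the exchange of dimethylamino for chloro, on the aromatic carbon next to the ring nitrogen, gives the first step that can be read at this position, a number at least 5 percentage points lower from compound 1 to compound 3 (that floor lies within the scatter), so the shared core gains nothing here from chloro, while whether the true gap exceeds the scatter cannot be told. The step is a floor and not a measured size, since the figure for compound 3 is bounded from one side only: the limit of < 5% in this assay, at which 1 of the 3 values shown sits.

The compounds shown leave open how a methoxy group, a methylamino group or a longer amine such as diethylamino would read at this position on the core of compound 1. Compound 2 differs from compound 1 in more than one place, so the figure of compound 2, 32%, cannot be credited to the group at this position and says nothing about which of its differences carries the figure.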